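The source may report more compounds than this note shows. Statements on the series, on what has been measured and on what is new or still open speak of the compounds shown alone.

Working notes on the series. Compound 1 `CNC(=O)N1CCCc2ccc(NC(=O)c3ccc(-c4ccn(C)n4)cc3)cc21` is the reference; in a functional assay on MV4-11 cells (Homo sapiens) for antiproliferative activity, with a stated time of 6 days, tested at 1.56 uM (a higher number here means a stronger effect of the compound at the concentration tested, a lower number a weaker effect), compound 1 gives 72.2%. Compound 2 `CNC(=O)N1CCCc2ccc(NC(=O)c3ccc(-c4cnn(S(C)(=O)=O)c4)cc3)cc21` carries a 1-(methylsulfonyl)-1H-pyrazol-4-yl in place of the 1-methyl-1H-pyrazol-3-yl of compound 1, and in this assay compound 2 gives 4.5%. For the measured compounds named here, the single measured step is a number 67.7 percentage points lower from compound 1 to compound 2 (beyond the scatter). Going by the values given here, on the two numbers available, compound 2 stands lowest, with compound 1 as its only neighbour, far higher.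

Compound 3 `CNC(=O)N1CCCc2ccc(NC(=O)c3ccc(-c4cnn(C(C)=O)c4)cc3)cc21` is not yet measured. Relative to compound 2 the change is acetyl in place of methylsulfonyl on an aromatic nitrogen. Among the compounds with values here, the one measured step bears on it only loosely: from compound 1 to compound 2 the ring attachment and the nitrogen substituent changed together, so the part owed to the substituent alone cannot be separated from a number 67.7 percentage points lower from compound 1 to compound 2 (beyond the scatter). Compound 3 keeps the 4-yl attachment of compound 2, so a recovery towards compound 1 is not expected; a small upward step is estimated, a number 10.5 percentage points higher from compound 2 to compound 3 (beyond the scatter), near the scatter. For compound 3 in this assay the estimate is 15%, with a range of 0% to 45%.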

Compound 3, a percentage reported as inhibition, at one concentration (the size of the read-out at that concentration, not a potency): 23.9%
The estimate for compound 3 lay 8.9 percentage points below the measured number; low and high end bracket the measured number.
By their numbers in this assay, from the lowest: compound 2; then compound 3; then compound 1.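

Working notes, continued. In this assay, the group on the aromatic nitrogen can now be read on its own with the 4-yl attachment held fixed: acetyl in place of methylsulfonyl gives a number 19.4 percentage points higher from compound 2 to compound 3 (beyond the scatter) and shows that this substituent alone moves the read-out. Even so, a number 48.3 percentage points lower from compound 1 to compound 3 (beyond the scatter) leaves compound 3 well short of the reference, so this exchange closes only a minor part of the gap, and the remaining step still combines a change of attachment with a change of nitrogen substituent. Nothing measured here accounts for the difference between acetyl and methylsulfonyl at this position.

The compounds shown leave open how the remaining gap divides between the 4-yl attachment and the nitrogen substituent, a split that 1-methyl-1H-pyrazol-4-yl would help resolve. Also open, on these data alone, is whether a longer chain on that aromatic nitrogen, such as an ethyl group or an aminoethyl group carrying a terminal amine, would read closer to compound 1 or to compound 3.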